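A few compounds are considered here, and "the series" means these few. Any claim that something is new, unique, unknown or untested is made for them only; others in the source may bear on it.

For the measured compounds named here, in a functional assay on WRL68 cells (Homo sapiens) for cytotoxicity, read by MTT assay, with stated times of 6 h and 48 h (on this read-out higher numbers stand for weaker inhibition and lower numbers for stronger inhibition), compound 1 `Cn1c(/C=C/C(=O)c2ccccc2O)cc(Br)c1Br` gives 330 nM, the lowest of the numbers measured so far. Compound 3 `COc1ccc(OC)c(C(=O)/C=C/c2cc(Br)c(Br)n2C)c1` gives 3270 nM. Compound 2 `Cn1c(/C=C/C(=O)c2ccccc2)cc(Br)c1Br` gives >= 100000 nM, which is a limit of the assay. Compound 4 `Cn1c(/C=C/C(=O)c2ccc(O)cc2O)cc(Br)c1Br` carries one change relative to compound 1, hydroxy in place of hydrogen on an aromatic carbon: hydroxy in place of hydrogen, meta to a hydroxy group and para to a large group. Going by the values given here, the only measured step that bears on this is large, an at least 300-fold higher number from compound 1 to compound 2 (2.48 log units; beyond the scatter), and it removes a hydroxy rather than adding one. Compound 4 keeps the hydroxy lost in that step, so no change beyond the scatter is expected in this assay. The expected step is a 1.5-fold higher number from compound 1 to compound 4 (0.18 log units; within the scatter). For compound 4 the estimated value is 500 nM, with an expected range from 120 nM to 2500 nM.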

Compound 4, half-maximal inhibitory concentration: 180 nM
Compound 4: the middle estimate sits 2.8-fold (0.44 log units) above what was measured; the range from low to high includes it.
By their numbers in this assay, from the lowest: compounds 4 and 1 (each within the scatter of the next); then compound 3. At a limit, above all of these: compound 2.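

In this assay, a hydroxy para to a large group and meta to a hydroxy group gives a 1.8-fold lower number from compound 1 to compound 4 (0.26 log units; within the scatter). The earlier compounds shown here showed only what losing the existing hydroxy does; this step shows that the ring carries a second hydroxy at this position with no change beyond the scatter. As far as these compounds go, the value of compound 2 is a limit, so the full size of the step that removes the first hydroxy stays unknown: the limit of >= 100000 nM in this assay, at which 1 of the 4 values shown sits. From the compounds shown here alone, whether an amine or a carboxylic acid at this position would also leave the number within the scatter remains open.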